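The source may report more compounds than this note shows. Statements on the series, on what has been measured and on what is new or still open speak of the compounds shown alone.

Measured so far in an ADME assay on PC-3 cells (Homo sapiens) for cytotoxicity, read by sulforhodamine B assay, with a stated time of 48 h, tested at 10 uM; a lower number here means less inhibition, a higher number more inhibition at the concentration tested (going by the name of the read-out):
compound 1, `COc1nc2ccc(Br)cc2cc1C(c1ccccc1)n1cc(-c2ccc(Br)cc2)nn1`, gives 7.43%
compound 2, `CCCCCCCCc1cn(C(c2ccccc2)c2cc3cc(Br)ccc3nc2OC)nn1`, gives 2.27%
compound 3, `COc1nc2ccc(Br)cc2cc1C(c1ccccc1)n1cc(-c2ccc(OC(F)(F)F)cc2)nn1`, gives 21.6%

Compound 3 stands highest of the three; compound 1 lies nearest and compound 2 furthest, both gaps beyond the scatter. Compound 4, `COc1nc2ccc(Br)cc2cc1C(c1ccccc1)n1cc(-c2cccc(F)c2)nn1`, differs from compound 3 by 3-fluorophenyl in place of 4-(trifluoromethoxy)phenyl on an aromatic carbon. The step of a number 14.2 percentage points higher from compound 1 to compound 3 (beyond the scatter) is the only one that touches this position, and it involved bromo against trifluoromethoxy, not fluoro; a number 5.2 percentage points lower from compound 1 to compound 2 (within the scatter) and a number 19.3 percentage points higher from compound 2 to compound 3 (beyond the scatter) concern a different replacement. Removing the trifluoromethoxy group that accompanied the highest value, a modest fall in this assay is expected for compound 4, of about a number 10.6 percentage points lower from compound 3 to compound 4 (beyond the scatter). Compound 4 is therefore estimated at 11%, within 0% to 25%.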

Compound 4, a percentage reported as inhibition, at one concentration (the size of the read-out at that concentration, not a potency): 14.6%
The estimate for compound 4 lay 3.6 percentage points below the measured number; the measured number falls inside the stated range.
By their numbers in this assay, from the lowest: compounds 2, 1, 4 and 3 (each within the scatter of the next, the first and the last beyond it).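

Replacing 4-(trifluoromethoxy)phenyl with 3-fluorophenyl on this aromatic carbon gave a number 7 percentage points lower from compound 3 to compound 4 (within the scatter) in this assay and so did not show that the trifluoromethoxy group is needed for the reading. Against octyl, 3-fluorophenyl gave a number 12.3 percentage points higher from compound 2 to compound 4 (beyond the scatter) and against 4-bromophenyl it gave a number 7.2 percentage points higher from compound 1 to compound 4 (within the scatter) so only the octyl compound stands apart from it. Nothing available explains these differences. As far as these compounds go, whether a phenyl group bearing an amine or a carboxylic acid at this place would raise the inhibition remains open. So does the role of where the fluorine sits, since this change altered both the substituent and its place on the phenyl group.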